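Swapping an octyl chain for an ester on the triazole

The source may report more compounds than this note shows. Statements on the series, on what has been measured and on what is new or still open speak of the compounds shown alone.

Compound 2 `CCCCCCCCc1cn(C(c2ccccc2)c2cc3cc(Br)ccc3nc2OC)nn1` is measured in an ADME assay on SK-OV-3 cells (Homo sapiens) for cytotoxicity, read by sulforhodamine B assay, with a stated time of 48 h, tested at 10 uM (on this read-out lower numbers stand for less inhibition and higher numbers for more inhibition at the one concentration tested (going by the name of the read-out)), where compound 2 gives 2.06%. Within the data shown here, its only measured neighbour, compound 1 `CCCCCCCc1cn(C(c2ccccc2)c2cc3cc(Br)ccc3nc2OC)nn1`, gives 10.5% in this assay; the step of a number 8.4 percentage points lower from compound 1 to compound 2 (within the scatter) is a chain extension by one carbon, so the two numbers cannot be told apart with confidence. Compound 3 `CCOC(=O)c1cn(C(c2ccccc2)c2cc3cc(Br)ccc3nc2OC)nn1` has not yet been measured in this assay. Relative to compound 2 the change is ethoxycarbonyl in place of octyl on an aromatic carbon. Among the measured compounds shown here, the one measured step, from compound 1 to compound 2, concerns only the length of the saturated chain and says nothing about replacing the whole chain with an ethoxycarbonyl group, so no measured step bears directly on this change. With both known numbers low and close together, a step of a number 3.9 percentage points higher from compound 2 to compound 3 (within the scatter) of no clear size beyond the scatter is expected. Compound 3 is therefore estimated at 6%, within a range from -10% to 25%.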

Compound 3, a percentage reported as inhibition, at one concentration (the size of the read-out at that concentration, not a potency): 2.01%
Compound 3: middle estimate off by 4 percentage points, on the high side, and the stated range covers the measured number.
By their numbers in this assay, from the lowest: compounds 3, 2 and 1 (each within the scatter of the next).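

In this assay, putting ethoxycarbonyl in place of octyl on this aromatic carbon gives a small step (a number 0.1 percentage points lower from compound 2 to compound 3 (within the scatter)), and putting it in place of heptyl gives another (a number 8.5 percentage points lower from compound 1 to compound 3 (within the scatter)). The earlier pair differed only in chain length, whereas here a saturated chain gives way to a shorter group with 2 hydrogen-bond acceptors and a double bond, and the numbers still cannot be told apart. Nothing available explains why this position shows no clear difference across these three groups.

The compounds shown leave open whether any group at this place can move the number beyond the scatter, for example a carboxylic acid, an amine or a much shorter chain such as methyl. They also leave open whether changes elsewhere on the shared core would do so.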